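The compounds below may be only part of what the source reports. "The series", "measured", "known", "first", "only" and "open" are said of these compounds alone.

Values in a functional assay on SEM cells (Homo sapiens) for inhibition, read by MTT assay, with a stated time of 72 h; a lower number here means a stronger inhibitor, a higher number a weaker inhibitor:

- Compound 1 `COc1cc(NC(=O)/C=C/c2cccc(OCc3ccccc3)c2)cc(OC)c1OC`: 8500 nM
- Compound 2 `C=C(Br)C(=O)Nc1cccc(/C=C/C(=O)Nc2ccccc2)c1`: 1100 nM
- Compound 3 `C=C(Br)C(=O)Nc1cccc(/C=C/C(=O)Nc2ccc(F)cc2)c1`: 8400 nM

Compound 3, at 8400 nM, stands level with compound 1, at 8500 nM, within the scatter of repeated measurements. Compound 2, at 1100 nM, gives a clearly lower number than compound 3.

The next compound to be tested is compound 4 `C=C(Br)C(=O)Nc1cccc(/C=C/C(=O)Nc2ccc(F)c(F)c2)c1`. It differs from compound 3 by one small change fluoro in place of hydrogen on an aromatic carbon, turning the 4-fluorophenyl into a 3,4-difluorophenyl. The new fluoro is ortho to a fluoro group and meta to a large group.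

Within the data shown here, only one measured step is of the same kind, a 7.6-fold higher number from compound 2 to compound 3 (0.88 log units; beyond the scatter). That modest step lies beyond the scatter and raised the number. It is a thin guide, however: it is a single case, and its fluoro went onto a ring that carried none, while here the ring already holds one. The data contain no second fluoro group to compare. A much smaller rise in this assay is therefore expected, perhaps none beyond the scatter, and a fall cannot be excluded.

The expected step is a 1.2-fold higher number from compound 3 to compound 4 (0.08 log units; within the scatter). For compound 4 the estimate is 10000 nM, with an expected range of 3500 nM to 30000 nM.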

Compound 4, half-maximal inhibitory concentration: 90 nM
Estimate against measurement, compound 4: 110-fold (2.05 log units) above; measured number below the stated range.
By their numbers in this assay, from the lowest: compound 4; then compound 2; then compounds 3 and 1 (each within the scatter of the next).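

In this assay, the same kind of change, fluoro in place of hydrogen on an aromatic carbon, can move the number in either direction: the first fluoro gave a 7.6-fold higher number from compound 2 to compound 3 (0.88 log units; beyond the scatter), while the second, ortho to a fluoro group, gave a 93-fold lower number from compound 3 to compound 4 (1.97 log units; beyond the scatter). The effect of adding a fluoro to this ring therefore depends on what the ring already carries, at least across compound 2, compound 3 and compound 4, and a single earlier step could not have shown this. The 3,4-difluorophenyl does more than undo the loss seen with the 4-fluorophenyl, since the comparison with the plain phenyl shows a 12-fold lower number from compound 2 to compound 4 (1.09 log units; beyond the scatter), and no measurement here explains this reversal.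

The compounds shown leave open whether the new fluoro would give a similar gain on a ring without the first one, and whether a chloro, methoxy or trifluoromethyl group in the same place would match it. They also leave open how much the bromine on the shared core contributes, for example compared with a chlorine or a hydrogen there.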